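This account rests on a few compounds, and the source may have more. Where it says the series, first, only, none or still open, it means among the compounds named here.

Compound 3 `O=C(O)/C=C/c1ccncc1-c1ccc2cc[nH]c2c1` carries a carboxy group on its side chain, while compound 1 `CNC(=O)/C=C/c1ccncc1-c1ccc2cc[nH]c2c1` carries a methylcarbamoyl group instead; the change is methylamino in place of hydroxy on a carbonyl carbon. In a functional assay on A549 cells (Homo sapiens) for inhibition, read by sulforhodamine B assay, with a stated time of 72 h (on this read-out lower numbers stand for stronger inhibition of growth and higher numbers for weaker inhibition of growth), compound 1 gives 7840 nM. For compound 3 the read-out in this assay is only a limit of the assay, > 10000 nM. The measured step, an at least 1.2-fold lower number from compound 3 to compound 1 (0.10 log units; that floor lies within the scatter), therefore rests on that limit, (the limit of > 10000 nM in this assay, at which 2 of the 3 values shown sit). Compound 2 `Cn1ccc2cc(-c3cnccc3/C=C/C(=O)O)ccc21` has a different core from compound 3; how the two cores differ is not broken down here. For compound 2 as well only a limit is known in this assay, > 10000 nM. Compound 4 `CNC(=O)/C=C/c1ccncc1-c1ccc2c(ccn2C)c1` relates to compound 2 exactly as compound 1 relates to compound 3, by the same change, (methylamino in place of hydroxy on a carbonyl carbon). A step of similar size is expected here, an at least 1.1-fold lower number from compound 2 to compound 4 (0.04 log units; that floor lies within the scatter), because the earlier step of an at least 1.2-fold lower number from compound 3 to compound 1 (0.10 log units; that floor lies within the scatter) came out small. Compound 4 is therefore estimated at 9000 nM, within 3000 nM to 30000 nM.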

Compound 4, concentration for 50% growth inhibition: 6450 nM
The estimate for compound 4 lay 1.4-fold (0.14 log units) above the measured number; measured number inside the range.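

Carrying the change of hydroxy to methylamino onto the core of compound 2 gives, in this assay, an at least 1.5-fold lower number from compound 2 to compound 4 (0.19 log units; that floor lies within the scatter). Compound 2 has only a limit of the assay, > 10000 nM, so this step is a floor, and it does not show a true gain in growth inhibition. Nor does it show whether the change acts alike on both cores, only that the two floors can be set side by side: the same change on two cores in this assay, an at least 1.2-fold lower number (0.10 log units; that floor lies within the scatter) from compound 3 to compound 1 and an at least 1.5-fold lower number (0.19 log units; that floor lies within the scatter) from compound 2 to compound 4; the limit leaves it open whether they differ

The compounds shown leave open how other groups on the carbonyl carbon, such as a plain amino group or ethylamino, would read. They also leave open whether a longer chain there would move the number beyond the usual scatter.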